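The compounds below may be only part of what the source reports. "The series", "measured", "known", "first", "only" and "open" are said of these compounds alone.

compound 1 `CCOc1ccc(-c2sc(N(C)C)nc2-c2cc(OC)c(OC)c(OC)c2)cc1`: 6030 nM
compound 2 `COc1cc(-c2nc(C)sc2-c2ccc(C(F)(F)F)cc2)cc(OC)c1OC`: 396 nM
compound 3 `COc1ccc(-c2sc(C)nc2-c2cc(OC)c(OC)c(OC)c2)cc1`: 1420 nM

In a functional assay on HT-29 cells (Homo sapiens) for antiproliferative activity, read by MTT assay, with a stated time of 72 h (on this read-out lower numbers stand for stronger inhibition and higher numbers for weaker inhibition), compound 3 gives 1420 nM and stands in the middle of the three, with compound 2 lower at 396 nM and compound 1 higher at 6030 nM on this read-out.

Compound 4 `CCOc1ccc(-c2sc(C)nc2-c2cc(OC)c(OC)c(OC)c2)cc1` follows from compound 3 through one change (methyl in place of hydrogen on a saturated chain carbon bound to an oxygen on an aromatic ring), methyl in place of hydrogen on a saturated chain carbon bound to an oxygen on an aromatic ring, which turns 4-methoxyphenyl to 4-ethoxyphenyl.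

Within the data shown here, no measured step makes this change. The nearest is a 3.6-fold higher number from compound 2 to compound 3 (0.55 log units; beyond the scatter) for methoxy in place of trifluoromethyl on an aromatic carbon, a modest step. Compound 1 also carries the ethoxy and gives 6030 nM but differs from compound 3 in a second place as well, so it does not isolate the change.

No shift beyond the scatter is therefore expected in this assay and no direction is settled. The expected step is a 1.3-fold lower number from compound 3 to compound 4 (0.11 log units; within the scatter) in this estimate. Compound 4 is estimated at 1100 nM with an expected range of 300 nM to 4000 nM on this read-out.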

Compound 4, half-maximal inhibitory concentration: 487 nM
Beside the measured number, compound 4's estimate is 2.3-fold (0.35 log units) above it; measured number inside the range.
By their numbers in this assay, from the lowest: compounds 2 and 4 (each within the scatter of the next); then compound 3; then compound 1.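

In this assay, among these compounds, the change from 4-methoxyphenyl to 4-ethoxyphenyl is now isolated for the first time, and it gives a 2.9-fold lower number from compound 3 to compound 4 (0.46 log units; beyond the scatter), so a single methyl added on the saturated chain carbon bound to an oxygen on an aromatic ring is enough to move the result beyond the scatter. Methoxy stood clearly apart from trifluoromethyl, but ethoxy does not, with a 1.2-fold higher number from compound 2 to compound 4 (0.09 log units; within the scatter). With the ethoxy held in place, the other substituent also counts, as methyl in place of dimethylamino gives a 12-fold lower number from compound 1 to compound 4 (1.09 log units; beyond the scatter).

This single pair cannot show whether a propoxy group or a longer chain would continue the trend or reverse it. The data shown offer no explanation for the effect of the added methyl.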